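The source may report more compounds than this note shows. Statements on the series, on what has been measured and on what is new or still open speak of the compounds shown alone.

In a functional assay on MDA-MB-231 cells (Homo sapiens), read by fluorescence and BrdU incorporation, with a stated time of 48 h, tested at 10 uM (a higher number here means a weaker effect of the compound at the concentration tested, a lower number a stronger effect), compound 1 `COc1cc(OC)c(C(=O)/C=C/c2ccc(Cl)cc2)c(OC)c1` gives 39%, compound 2 `COc1cc(OC)c(C(=O)/C=C/c2ccc(Br)cc2)c(OC)c1` gives 42%, and compound 3 `COc1cc(OC)c(C(=O)/C=C/c2ccccc2SC)c(OC)c1` gives 48%, the highest of the three numbers, although the steps of a number 9 percentage points higher from compound 1 to compound 3 (within the scatter) and a number 6 percentage points higher from compound 2 to compound 3 (within the scatter) both stay within the scatter, as does a number 3 percentage points higher from compound 1 to compound 2 (within the scatter). Compound 4 `COc1cc(O)c(C(=O)/C=C/c2ccccc2SC)c(OC)c1` differs from compound 3 in one place: hydrogen in place of methyl on an oxygen on an aromatic ring. None of the three measured steps touches this oxygen; all of them alter the part of the molecule that carries the chloro, bromo or methylsulfanyl group. Among the measured compounds shown here, no measured step therefore bears on this change, and no shift beyond the scatter is expected in this assay for the step of no change at the digits printed from compound 3 to compound 4 (within the scatter). Compound 4 is estimated at 48%, between 25% and 70%.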

Compound 4, a percentage reported as activity, at one concentration (the size of the read-out at that concentration, not a potency): "not active" (no number reported)
The entry for compound 4 holds no number, so the estimate cannot be set against anything.
By their numbers in this assay, from the lowest: compounds 1, 2 and 3 (each within the scatter of the next).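

Among the compounds shown here, compound 4 is reported only as "not active", with no number, so no step from compound 3 to compound 4 can be read. Nothing shown here explains that entry. As far as these compounds go, how far methoxy to hydroxy shifts the read-out stays open.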